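Trifluoromethyl for methyl on the oxime benzyl group

The source may report more compounds than this note shows. Statements on the series, on what has been measured and on what is new or still open speak of the compounds shown alone.

Measured compounds:
compound 1, `Cc1ccc(CO/N=C2/C(c3c[nH]c4ccccc34)=Nc3ccccc32)cc1`, 19100 nM in a functional assay on HepG2 cells (Homo sapiens) for cytotoxicity, read by MTT assay, with a stated time of 2 days; on this read-out higher numbers stand for weaker inhibition and lower numbers for stronger inhibition
compound 2, `Cc1ccc(CO/N=C2/C(c3c[nH]c4ccc(Br)cc34)=Nc3ccc(Br)cc32)cc1`, 20400 nM

Compound 2 carries two bromine atoms on its core, whereas compound 1 has none, and both share the 4-methylbenzyl oxime ether. Among the two numbers available, compound 2 has the higher one, with compound 1 close by; the gap between them is within the scatter, so the two values cannot be told apart.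

Compound 3, `FC(F)(F)c1ccc(CO/N=C2/C(c3c[nH]c4ccc(Br)cc34)=Nc3ccc(Br)cc32)cc1`, keeps the brominated core of compound 2 and alters only the benzyl group: trifluoromethyl in place of methyl on an aromatic carbon, the same difference read one bond further out being 4-methylbenzyl to 4-(trifluoromethyl)benzyl. Within the data shown here, no measured pair shows what this change does in this assay. With the two measured compounds sitting so near each other, and no guide to the effect of the trifluoromethyl group, the step from compound 2 to compound 3 is expected to stay small, most likely within the scatter, as a 1.1-fold lower number from compound 2 to compound 3 (0.05 log units; within the scatter). Compound 3 is therefore estimated at 18000 nM, with a range from 8000 nM to 45000 nM.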

Compound 3, half-maximal inhibitory concentration: 11100 nM
Compound 3: middle estimate off by 1.6-fold (0.21 log units), on the high side, and the stated range covers the measured number.
By their numbers in this assay, from the lowest: compounds 3, 1 and 2 (each within the scatter of the next).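

In this assay, the substituent on the benzyl ring of the oxime ether now has its first measured pair: with the shared core held constant, putting trifluoromethyl in place of methyl on this aromatic carbon, para to a large group, gives a 1.8-fold lower number from compound 2 to compound 3 (0.26 log units; within the scatter). Compounds 1 and 2 both carry the 4-methylbenzyl group and so could say nothing about this site, whereas this pair shows that the exchange from 4-methylbenzyl to 4-(trifluoromethyl)benzyl does not carry the read-out beyond the usual scatter of the measurement. Nothing measured among these compounds offers an explanation for this small step, and it cannot be taken as a real gain or loss in either direction.

The compounds shown leave open whether the same exchange behaves alike on the core without bromine, as that core is represented here only by its 4-methylbenzyl member, compound 1. They also leave open whether a quite different group on the same aromatic carbon, such as an amine, a carboxylic acid or a longer alkyl chain, would produce a step beyond the scatter in this assay.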